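Pendant aryl exchange on the shared core: compound 4

The compounds below may be only part of what the source reports. "The series", "measured", "known", "first", "only" and "open" are said of these compounds alone.

Compound 3 `CCOc1ccc(-c2ccc3ncn(-c4cc(OC)c(OC)c(OC)c4)c3c2)cc1` carries the highest of the three numbers in a functional assay on SGC-7901 cells (Homo sapiens) for antiproliferative activity, read by MTT assay, with a stated time of 72 h; a lower number here means a stronger inhibitor, a higher number a weaker inhibitor: compound 3 gives 2970 nM, whereas compound 1 `COc1cc(-n2cnc3ccc(-c4ccc(Cl)cc4)cc32)cc(OC)c1OC` gives 1270 nM and compound 2 `COc1cc(-n2cnc3ccc(-c4cccc(O)c4)cc32)cc(OC)c1OC` gives 53 nM. Compound 4 `COc1cc(-n2cnc3ccc(-c4cccc(Cl)c4)cc32)cc(OC)c1OC` differs from compound 3 by 3-chlorophenyl in place of 4-ethoxyphenyl on an aromatic carbon. Among the compounds with values here, two measured steps bear on this. The modest 2.3-fold higher number from compound 1 to compound 3 (0.37 log units; beyond the scatter) suggests that putting chloro back in place of ethoxy should lower the number a little. Within the data shown here, the large 56-fold higher number from compound 2 to compound 3 (1.75 log units; beyond the scatter) and a 24-fold lower number from compound 1 to compound 2 (1.38 log units; beyond the scatter) show that a 3-hydroxyphenyl sits far below both 4-ethoxyphenyl and 4-chlorophenyl, but a 3-chlorophenyl has no measured precedent, so the shift of position adds uncertainty. A lower number is therefore expected, a 5.0-fold lower number from compound 3 to compound 4 (0.69 log units; beyond the scatter). Compound 4 is estimated at 600 nM, between 150 nM and 2500 nM.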

Compound 4, half-maximal inhibitory concentration: 1490 nM
Compound 4: the middle estimate sits 2.5-fold (0.40 log units) below what was measured; the range from low to high includes it.
By their numbers in this assay, from the lowest: compound 2; then compounds 1, 4 and 3 (each within the scatter of the next, the first and the last beyond it).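

3-chlorophenyl in place of 4-chlorophenyl gives a 1.2-fold higher number from compound 1 to compound 4 (0.07 log units; within the scatter) and 3-chlorophenyl in place of 4-ethoxyphenyl gives a 2.0-fold lower number from compound 3 to compound 4 (0.30 log units; within the scatter), so neither change separates its pair. With the position held, chloro in place of hydroxy gives a 28-fold higher number from compound 2 to compound 4 (1.45 log units; beyond the scatter), so the low number of compound 2 goes with the hydroxy group and not with that ring position alone. Nothing available explains this difference. From the compounds shown here alone, whether an amine or a carboxylic acid in place of the hydroxy group would keep a number near that of compound 2 remains open.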